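This account rests on a few compounds, and the source may have more. Where it says the series, first, only, none or still open, it means among the compounds named here.

Three measured compounds share one core and a sulfonyl group carrying a small ring. Compound 1 `CN1CCN(S(=O)(=O)c2ccc(C3=CC4C(Nc5ccc(OCc6cccc(F)c6)c(Cl)c5)=NC=NC4S3)cc2)CC1` was tested in a toxicity assay on HepG2 cells (Homo sapiens) for cytotoxicity, read by MTT assay, with a stated time of 48 h; a higher number here means that more compound is tolerated, a lower number that less compound is tolerated; compound 1 gives > 15 uM, which is a limit of the assay rather than a number. Compound 3 `CN1CCN(S(=O)(=O)c2ccc(C3=CC4N=CN=C(Nc5ccc(OCc6cccc(F)c6)c(Cl)c5)C4S3)cc2)CC1` gives > 15 uM, again a limit. Compound 2 `CN1CCCN(S(=O)(=O)c2ccc(C3=CC4N=CN=C(Nc5ccc(OCc6cccc(F)c6)c(Cl)c5)C4S3)cc2)CC1` gives > 15 uM, also a limit. Compound 2 differs from compound 3 by 4-methyl-1,4-diazepan-1-yl in place of 4-methylpiperazin-1-yl on a sulfonyl sulfur, and the step that the two limits leave unreadable from compound 3 to compound 2 cannot be sized from two limits. Compound 1 and compound 3 have the same atoms joined differently; the difference between the two cores is not broken down here. Compound 4 `CN1CCCN(S(=O)(=O)c2ccc(C3=CC4C(Nc5ccc(OCc6cccc(F)c6)c(Cl)c5)=NC=NC4S3)cc2)CC1` differs from compound 1 by 4-methyl-1,4-diazepan-1-yl in place of 4-methylpiperazin-1-yl on a sulfonyl sulfur, the same change. Because (the limit of > 15 uM in this assay, at which 3 of the 3 values shown sit), compound 4 is expected to sit at a limit as well, an expected step that the limit leaves unreadable from compound 1 to compound 4 in this assay. The estimate for compound 4 is 20 uM.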

Compound 4, half-maximal toxic concentration: > 15 uM
Compound 4: no number, only a limit (the forecaster's own chance of this, stated with the estimate: 85%); the middle value is on the limit's open side.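

No step can be read from compound 1 to compound 4, because both give only a limit in this assay: the limit of > 15 uM in this assay, at which 4 of the 4 values shown sit. Where the true toxic concentration of each of these compounds lies, and whether the ring change shifts it, remains open.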